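A few compounds are considered here, and "the series" means these few. Any claim that something is new, unique, unknown or untested is made for them only; others in the source may bear on it.

Measured compounds in a physicochemical assay for solubility, read by spectrophotometry, in phosphate buffer, measured as kinetic solubility, with a stated time of 18 h, at pH 7.4; on this read-out lower numbers stand for lower solubility and higher numbers for higher solubility:
- compound 1, `O=C(Nc1cccc(-c2nc3ccccc3s2)c1)c1cc([N+](=O)[O-])c(O)cc1Cl`: 2200 nM
- compound 2, `O=C(Nc1ccc(F)c(-c2nc3ccccc3s2)c1)c1cc([N+](=O)[O-])ccc1Cl`: 490 nM
- compound 3, `O=C(Nc1ccc(-c2ccccc2)cc1)c1cc([N+](=O)[O-])ccc1Cl`: 120 nM

Compound 1 stands highest of the three numbers in this assay. Its gap to compound 2 is the nearest and is beyond the scatter; its gap to compound 3 is the widest and is also beyond the scatter. Among the measured compounds shown here, no two of the measured compounds differ in one place only, so no single structural step within the measured set can be read, and the three numbers are taken as they stand.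

Compound 4, `O=C(O)COc1cc(Cl)c(C(=O)Nc2cccc(-c3nc4ccccc4s3)c2)cc1[N+](=O)[O-]`, has not yet been measured in this assay. It differs from compound 1 by carboxymethyl in place of hydrogen on an oxygen on an aromatic ring. The change leaves the shared core of compound 1 intact and adds the carboxymethyl on the oxygen on the aromatic ring.

With no measured step of this kind in the set, the expectation rests on compound 1 alone: the step from compound 1 to compound 4 is estimated as a 3.6-fold higher number from compound 1 to compound 4 (0.56 log units; beyond the scatter), upward and beyond the scatter. Compound 4 is therefore expected to give 8000 nM in this assay, with a range of 2500 nM to 30000 nM.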

Compound 4, solubility: 6700 nM
Compound 4: middle estimate off by 1.2-fold (0.08 log units), on the high side; the range from low to high includes it.
By their numbers in this assay, from the lowest: compound 3; then compound 2; then compound 1; then compound 4.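

In this assay the series now has its first step that changes one place only: carboxymethyl in place of hydrogen on an oxygen on an aromatic ring gives a 3.0-fold higher number from compound 1 to compound 4 (0.48 log units; beyond the scatter) and counts as a modest step. The earlier compounds shown here offered no such pair, so their numbers could only be set side by side, whereas this step ties a change in the read-out to one named place with the shared core of compound 1 left intact. Nothing at hand explains the upward move, so the step stands as an observation about this one pair and gives no mechanism.

Still open, on these data alone, is how much of the step belongs to the carboxymethyl as a whole, and whether a plain methyl on the same oxygen, a longer chain ending in a carboxylic acid, or a chain ending in an amine would move the number in the same direction or by a similar amount. As far as these compounds go, with a single pair behind it, the step also cannot be read as a rule for the series, and whether it carries over to other cores remains unknown.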